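A few compounds are considered here, and "the series" means these few. Any claim that something is new, unique, unknown or untested is made for them only; others in the source may bear on it.

Measured so far in a functional assay on HCT-116 cells (Homo sapiens) for inhibition, read by CCK-8 assay, with a stated time of 72 h, tested at 8 uM; on this read-out lower numbers stand for less inhibition of growth and higher numbers for more inhibition of growth at the one concentration tested:
- compound 1 `COc1ccc(SCc2ccc(C(=O)Nc3ccccc3N)cc2)cc1` gives 90.1%
- compound 2 `Nc1ccccc1NC(=O)c1ccc(CSc2cccc(F)c2)cc1` gives 81.4%
- compound 3 `Nc1ccccc1NC(=O)c1ccc(CSc2ccc(Br)cc2)cc1` gives 67.7%

Compound 3 stands lowest of the three in this assay, with compound 2 the nearest and compound 1 the furthest. Two measured steps end at it: a number 13.7 percentage points lower from compound 2 to compound 3 (beyond the scatter) and a number 22.4 percentage points lower from compound 1 to compound 3 (beyond the scatter) on the same read-out. The remaining step (a number 8.7 percentage points lower from compound 1 to compound 2 (within the scatter)) joins the other two compounds.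

Among the compounds with values here, the next compound is compound 4 `Nc1ccccc1NC(=O)c1ccc(CSCCc2ccccc2)cc1`, which carries phenethyl in place of 4-bromophenyl on a sulfur as its one change. All three measured steps exchange one substituted phenyl group for another on the sulfur. None of them brings a phenethyl there, so they bear on this change only indirectly and give a rough size for exchanges at this place, not a direct precedent. Compound 3 at 67.7% sits under both other values, so a new group on the sulfur has more room to lead upward than downward. A small rise is expected, no larger than the measured steps: the estimated step is a number 7.3 percentage points higher from compound 3 to compound 4 (within the scatter) in this series. For compound 4 the estimated value is 75% with an expected range from 55% to 90% as the working figure.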

Compound 4, percent growth inhibition at one concentration: 81.3%
Estimate against measurement, compound 4: 6.3 percentage points below, and the stated range covers the measured number.
By their numbers in this assay, from the lowest: compound 3; then compounds 4, 2 and 1 (each within the scatter of the next).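

In this assay, within the data shown here, phenethyl is the first group on the sulfur whose aromatic ring does not stand directly on that sulfur, and this change from 4-bromophenyl gives a number 13.6 percentage points higher from compound 3 to compound 4 (beyond the scatter). The same group stays level with the two other aryl groups, with a number 0.1 percentage points lower from compound 2 to compound 4 (within the scatter) and a number 8.8 percentage points lower from compound 1 to compound 4 (within the scatter), so a phenyl directly on the sulfur is not needed to reach the range of compound 1 and compound 2, and compound 3 alone now stands apart from the other three. Nothing at hand explains why the 4-bromophenyl compound stands apart or why phenethyl matches the aryl groups.

Still open, going by these compounds, is how the read-out responds to the chain itself: a benzyl group, a longer chain ending in phenyl, or a phenethyl with methoxy or bromo on its ring could each separate the effect of the chain from that of the ring substituent, and an amine or a carboxylic acid at the end of the chain would test whether the aromatic ring is needed at all. A single concentration also leaves compound 1, compound 2 and compound 4 unseparated, so any order among them would need full concentration-response data.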